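The source may report more compounds than this note shows. Statements on the series, on what has been measured and on what is new or still open speak of the compounds shown alone.

Three compounds share one core and differ only in the aromatic group carried on a nitrogen on an aromatic ring in a ring. Compound 1 `CC(C)OC(=O)N1CCC(Oc2ncnc3c2CCN3c2ccc(S(C)(=O)=O)cn2)CC1`, which bears 5-(methylsulfonyl)pyridin-2-yl there, gives 126 nM in a functional assay on CHO-K1 cells for agonist activity at Glucose-dependent insulinotropic receptor (Homo sapiens), read by a luciferase reporter, with a stated time of 5 h; on this read-out higher numbers stand for an effect only at larger amounts of compound and lower numbers for an effect already at smaller amounts. Compound 2 `Cc1ncccc1N1CCc2c(OC3CCN(C(=O)OC(C)C)CC3)ncnc21`, with 2-methylpyridin-3-yl in that place, reaches only a limit of the assay, > 10000 nM. Compound 3 `CSc1ccc(N2CCc3c(OC4CCN(C(=O)OC(C)C)CC4)ncnc32)cc1F` gives 398 nM, the highest of the two actual numbers, its nearest neighbour being compound 1.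

Compound 4 `Cc1cc(S(C)(=O)=O)ccc1N1CCc2c(OC3CCN(C(=O)OC(C)C)CC3)ncnc21` is not yet measured. Its change from compound 3 is a group of 11 heavy atoms (8 carbon, 2 oxygen, 1 sulfur; one six-membered aromatic ring of carbon only) in place of a group of 9 heavy atoms (7 carbon, 1 fluorine, 1 sulfur; one six-membered aromatic ring of carbon only), on a nitrogen on an aromatic ring in a ring. For the measured compounds named here, two measured steps bear on this. The step of a 3.2-fold higher number from compound 1 to compound 3 (0.50 log units; beyond the scatter) shows that swapping a methylsulfonyl-bearing ring for the fluoro methylthio ring costs a modest amount, so going back to a methylsulfonyl-bearing ring might recover it. The step of an at least 79-fold higher number from compound 1 to compound 2 (1.89 log units; beyond the scatter) shows that a small methylpyridine ring loses activity entirely, marked by the limit of > 10000 nM in this assay, at which 1 of the 3 values shown sits; compound 4 keeps the methylsulfonyl group, so that loss is not expected here. A modest step downward, a 2.5-fold lower number from compound 3 to compound 4 (0.40 log units; beyond the scatter), is therefore expected. For compound 4 the estimate is 160 nM, within a range from 50 nM to 500 nM.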

Compound 4, half-maximal effective concentration: 100 nM
Compound 4: the middle estimate sits 1.6-fold (0.20 log units) above what was measured; the measured number falls inside the stated range.
By their numbers in this assay, from the lowest: compounds 4 and 1 (each within the scatter of the next); then compound 3. At a limit, above all of these: compound 2.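

In this assay, the step of a 4.0-fold lower number from compound 3 to compound 4 (0.60 log units; beyond the scatter) shows that this nitrogen tolerates a carbon-only aromatic ring well when that ring is 2-methyl-4-(methylsulfonyl)phenyl, whereas the fluorine- and sulfur-bearing ring of compound 3 gave a higher number. The step of a 1.3-fold lower number from compound 1 to compound 4 (0.10 log units; within the scatter) lies within the scatter, so the two methylsulfonyl-bearing rings cannot be told apart here, and the nitrogen in the aromatic ring of compound 1 is not required to reach this level. The step of an at least 100-fold lower number from compound 2 to compound 4 (2.00 log units; beyond the scatter) starts from the entry for compound 2, which is a limit and not a number, so its full size stays unknown, yet it shows that a 2-methyl group on the ring does not by itself give activity: the limit of > 10000 nM in this assay, at which 1 of the 4 values shown sits.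

What the 2-methyl group adds in compound 4 remains open, as no compound shown pairs the same carbon-only ring and methylsulfonyl group without it. As far as these compounds go, it is also open whether a nitrile or a sulfonamide in place of the methylsulfonyl group would keep the number this low.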